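The source may report more compounds than this note shows. Statements on the series, on what has been measured and on what is new or still open speak of the compounds shown alone.

Measured so far in a physicochemical assay for solubility, in phosphate buffer, with a stated time of 18 h, at pH 7; a lower number here means a less soluble compound, a higher number a more soluble compound:
- compound 1 `CC(C)CN1C(=O)c2ccccc2[C@H](C(=O)Nc2ccc(F)c(C#N)c2)[C@H]1c1ccc(C(N)=O)s1`: 19000 nM
- compound 2 `CC(C)CN1C(=O)c2ccccc2[C@H](C(=O)Nc2ccc(F)c(C#N)c2)[C@H]1c1cccnc1`: 55000 nM

Compound 2 has the higher of the two numbers, at 55000 nM. The next compound, compound 3 `CC(C)CN1C(=O)c2ccccc2[C@H](C(=O)Nc2ccc(F)c(C#N)c2)[C@H]1c1cncs1`, keeps the same core and changes one group: 1,3-thiazol-5-yl in place of pyridin-3-yl on a saturated ring carbon. This swap sits on a saturated ring carbon, next to the ring nitrogen.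

Among the measured compounds shown here, only one measured step bears on it, and it involves the same place on the core: a 2.9-fold higher number from compound 1 to compound 2 (0.46 log units; beyond the scatter). That step is modest, and a single step is thin evidence. For the measured compounds named here, no compound carrying 1,3-thiazol-5-yl has been measured yet. Still, 1,3-thiazol-5-yl is a five-membered aromatic ring, as is the 5-carbamoylthiophen-2-yl of compound 1, which gives 19000 nM. On that resemblance, a small move down in this assay is expected, no larger than the measured step and possibly lost in the scatter. The estimated change is a 1.7-fold lower number from compound 2 to compound 3 (0.22 log units; within the scatter). For compound 3 the expected value is 33000 nM, with an estimated range of 12000 nM to 75000 nM.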

Compound 3, solubility: 63000 nM
Compound 3: middle estimate off by 1.9-fold (0.28 log units), on the low side; measured number inside the range.
By their numbers in this assay, from the lowest: compound 1; then compounds 2 and 3 (each within the scatter of the next).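

In this assay, replacing the six-membered aromatic ring with a five-membered one on this saturated ring carbon gives a 1.1-fold higher number from compound 2 to compound 3 (0.06 log units; within the scatter) and so does not separate the two compounds. The second step, a 3.3-fold higher number from compound 1 to compound 3 (0.52 log units; beyond the scatter), shows that a five-membered aromatic ring at this place does not by itself go with a lower number: of the three compounds, only compound 1, which carries the 5-carbamoylthiophen-2-yl group and gives 19000 nM, stands apart from the other two. Nothing available explains why the numbers fall this way, and no measurement of any underlying property accompanies them.

The three compounds cannot show whether the lower number of compound 1 goes with its thiophene ring, with the carbamoyl group on that ring, or with both, so a plain thiophen-2-yl at this place would be an informative comparison. Going by these compounds, it also remains open how this assay would respond to a ring carrying an amine or a carboxylic acid here, or to a longer chain in place of the isobutyl group on the ring nitrogen.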